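Swapping the Benzimidazole for a Trifluoromethylbenzyl Group

A few compounds are considered here, and "the series" means these few. Any claim that something is new, unique, unknown or untested is made for them only; others in the source may bear on it.

Of the compounds shown here, three sharing one core have been tested in a toxicity assay on GES1 cells (Homo sapiens) for inhibition, read by MTT assay, with a stated time of 72 h; a higher number here means a weaker inhibitor, a lower number a stronger inhibitor. Compound 1, `Cc1cc(N2CC[C@@H](C)[C@@H](N(C)c3ncnc4[nH]ccc34)C2)n2nc(SCc3nc4ccccc4[nH]3)nc2n1`, gives 40200 nM in this assay, the highest of the two numbers seen, so among the measured pair it is the weaker inhibitor. Its nearest neighbour, compound 2, `Cc1cc(N2CC[C@@H](C)[C@@H](N(C)c3ncnc4[nH]ccc34)C2)n2nc(SCc3ccc(F)cc3)nc2n1`, gives 12300 nM. Compound 3, `C=CCSc1nc2nc(C)cc(N3CC[C@@H](C)[C@@H](N(C)c4ncnc5[nH]ccc45)C3)n2n1`, reached only a limit of this assay, > 100000 nM, so no number is known for it (the limit of > 100000 nM in this assay, at which 1 of the 3 values shown sits).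

The change from compound 1 to compound 4, `Cc1cc(N2CC[C@@H](C)[C@@H](N(C)c3ncnc4[nH]ccc34)C2)n2nc(SCc3ccc(C(F)(F)F)cc3)nc2n1`, is 4-(trifluoromethyl)phenyl in place of 1H-benzimidazol-2-yl on a saturated chain carbon bound to a sulfur. The step that bears most directly on it is a 3.3-fold lower number from compound 1 to compound 2 (0.51 log units; beyond the scatter), where a substituted phenyl ring likewise entered at the same place. The steps of an at least 2.4-fold higher number from compound 1 to compound 3 (0.39 log units; beyond the scatter) and an at least 8.1-fold higher number from compound 2 to compound 3 (0.91 log units; beyond the scatter) show that leaving no aromatic ring there pushed the number up, toward weaker inhibition. Compound 4 keeps an aromatic ring, so a modest step down, similar to that for compound 2, is expected. Compound 4 is therefore estimated at 10000 nM, with a range of 3000 nM to 35000 nM. This expected change amounts to a 4.0-fold lower number from compound 1 to compound 4 (0.60 log units; beyond the scatter).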

Compound 4, half-maximal inhibitory concentration: 17300 nM
The estimate for compound 4 lay 1.7-fold (0.24 log units) below the measured number; measured number inside the range.
By their numbers in this assay, from the lowest: compounds 2 and 4 (each within the scatter of the next); then compound 1. At a limit, above all of these: compound 3.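

Within the data shown here, a second substituted phenyl ring on the saturated chain carbon bound to a sulfur also lowers the number in this assay, with a 2.3-fold lower number from compound 1 to compound 4 (0.37 log units; beyond the scatter) as the step, so compound 2 is no longer the only example. Trifluoromethyl in place of fluoro on the aromatic carbon gives a 1.4-fold higher number from compound 2 to compound 4 (0.15 log units; within the scatter) and so separates compound 2 from compound 4 by nothing the assay can resolve. The comparison with the vinyl group gives an at least 5.7-fold lower number from compound 3 to compound 4 (0.76 log units; beyond the scatter) and adds a second phenyl compound to that contrast, but its starting point is only a limit: the limit of > 100000 nM in this assay, at which 1 of the 4 values shown sits.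

An unsubstituted phenyl ring at this place would show whether the ring alone accounts for these steps. Going by these compounds, how a chain ending in an amine or a carboxylic acid would read in this assay remains open.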